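Working notes: aryl swap at the aromatic carbon of compound 3

The source may report more compounds than this note shows. Statements on the series, on what has been measured and on what is new or still open speak of the compounds shown alone.

Measured in an assay on HEK293 cells for activation of Kir3.1/Kir3.2 (Homo sapiens), read by thallium flux; on this read-out higher numbers stand for larger maximal responses and lower numbers for smaller maximal responses:
compound 1 `Cc1cc(NC(=O)Cn2nnc(-c3ccccc3)n2)n(CC2CCCCC2)n1` gives 77%
compound 2 `Cc1cc(NC(=O)Cn2nnc(-c3ccccc3)n2)n(-c2ccccc2)n1` gives 66%
compound 3 `Cc1cc(NC(=O)Cn2nnc(-c3cccnc3)n2)n(C2CCCCC2)n1` gives 96%

Compound 3 stands highest of the three numbers in this assay; compound 1 sits nearest below it and compound 2 furthest below, both gaps beyond the scatter. The next compound, compound 4 `Cc1cc(NC(=O)Cn2nnc(-c3cccc(C(F)(F)F)c3)n2)n(C2CCCCC2)n1`, differs from compound 3 by 3-(trifluoromethyl)phenyl in place of pyridin-3-yl on an aromatic carbon.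

Within the data shown here, the only measured step between single-place neighbours, a number 11 percentage points lower from compound 1 to compound 2 (beyond the scatter), concerns the group on the aromatic nitrogen, not the aromatic carbon changed here, so it does not bear on this change directly. Compounds 1 and 2 carry a carbon-only ring at the aromatic carbon where compound 3 carries pyridin-3-yl, but each also differs from compound 3 on the aromatic nitrogen, so no clean comparison exists. Among the measured compounds shown here, their values both lie below that of compound 3, which weakly points toward a smaller maximal response when the ring nitrogen is absent; the trifluoromethyl group has no precedent in this set.

On that basis a modest step down is expected, a number 16 percentage points lower from compound 3 to compound 4 (beyond the scatter), with wide uncertainty. Compound 4 is estimated at 80%, range 60% to 100%.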

Compound 4, largest response reached (Emax), in percent of the reference or control that the assay uses: 86%
Estimate against measurement, compound 4: 6 percentage points below; the range from low to high includes it.
By their numbers in this assay, from the lowest: compound 2; then compounds 1, 4 and 3 (each within the scatter of the next, the first and the last beyond it).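

In this assay, among these compounds, the exchange on the aromatic carbon of the five-membered aromatic ring with 4 nitrogen gives a number 10 percentage points lower from compound 3 to compound 4 (within the scatter), the first comparison at this position with nothing else altered. Across this pair, the maximal response cannot be told apart even though pyridin-3-yl, with its ring nitrogen and 1 hydrogen-bond acceptor, gives way to 3-(trifluoromethyl)phenyl, with a carbon-only aromatic ring, 0 hydrogen-bond acceptors and 10 heavy atoms instead of 6, so with cyclohexyl on the aromatic nitrogen this position accepts both groups without a step beyond the scatter. No measured property of either group bears on this result, so the compounds give no explanation for it.

Going by these compounds, whether the trifluoromethyl group matters in its own right remains open, as does what unsubstituted phenyl would give on the core of compound 3, since the two compounds carrying phenyl here also differ on the aromatic nitrogen. It is also unknown how far the tolerance at this position extends, for instance to a nitrile or a methoxy group on the phenyl ring, to an amine or a carboxylic acid there, or to a non-aromatic ring such as piperidine.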